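Working notes: bromo for trifluoromethyl in the series

This account rests on a few compounds, and the source may have more. Where it says the series, first, only, none or still open, it means among the compounds named here.

Compound 1 `Cc1ccc(NC(=O)C2CCN(C/C=C/c3ccccc3)CC2)cc1` gives 30000 nM
Compound 2 `O=C(Nc1cccc(C(F)(F)F)c1)C1CCN(C/C=C/c2ccccc2)CC1` gives 16100 nM

Both values come from a functional assay on MCF7 cells (Homo sapiens) for inhibition, read by MTT assay, with a stated time of 72 h (a lower number here means a stronger inhibitor, a higher number a weaker inhibitor), and lie within the scatter of each other, so compound 2 at 16100 nM cannot be ranked apart from compound 1. Compound 3 `O=C(Nc1cccc(Br)c1)C1CCN(C/C=C/c2ccccc2)CC1` carries bromo in place of trifluoromethyl on an aromatic carbon, meta to a large group: bromo in place of trifluoromethyl on an aromatic carbon. Going by the values given here, no measured pair differs in one place only, so the data give no direct size for this change. No step beyond the scatter is expected in this assay, in either direction, and compound 2 at 16100 nM serves as the anchor. The estimated step of a 1.1-fold higher number from compound 2 to compound 3 (0.05 log units; within the scatter) is expected to stay within the scatter. For compound 3 the expected value is 18000 nM, with an estimated range from 8000 nM to 40000 nM.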

Compound 3, half-maximal inhibitory concentration: 11500 nM
Estimate against measurement, compound 3: 1.6-fold (0.19 log units) above, and the stated range covers the measured number.
By their numbers in this assay, from the lowest: compounds 3, 2 and 1 (each within the scatter of the next, the first and the last beyond it).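

In this assay the step for bromo in place of trifluoromethyl on this aromatic carbon, meta to a large group, now has a direct size (a 1.4-fold lower number from compound 2 to compound 3 (0.15 log units; within the scatter)), so the two groups cannot be told apart at this position. Going by these compounds alone, the wider replacement, 3-bromophenyl in place of 4-methylphenyl on the amide-type nitrogen, gives the first step beyond the scatter, though only a modest one (a 2.6-fold lower number from compound 1 to compound 3 (0.42 log units; beyond the scatter)). Nothing in hand accounts for either step.

Still open, as far as these compounds go, is whether a nitrile, a methoxy group, an amine or a carboxylic acid on this aromatic carbon would read any differently from bromo. Also open, from the compounds shown here alone, is how the step from 4-methylphenyl to 3-bromophenyl divides between the group itself and its place on the ring.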